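Open-chain analogues in the electroshock series: methyl for chloro

The compounds below may be only part of what the source reports. "The series", "measured", "known", "first", "only" and "open" are said of these compounds alone.

Compound 1 `O=C1CCC2(c3ccc(F)cc3)OCCCN12` gives 68.7 mg/kg in a functional assay on the whole organism with Mus musculus as the target, in the maximal electroshock model (a lower number here means that less compound is needed, a higher number that more compound is needed for the effect), and compound 2 `O=C1CCC2(c3ccc(Cl)c(Cl)c3)OCCCN12` gives 113 mg/kg. Compound 3 `O=C(CCC(=O)c1ccc(Cl)cc1)NCCCO` is the open-chain member; for compound 3 this assay reports only a limit, > 300 mg/kg. That limit is the line at which one of the three values sits (the limit of > 300 mg/kg in this assay, at which 1 of the 3 values shown sits), so compound 3 has no number to compare against compound 1 or compound 2.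

Compound 4 `Cc1ccc(C(=O)CCC(=O)NCCCO)cc1` differs from compound 3 by methyl in place of chloro on an aromatic carbon. Within the data shown here, no measured step of this kind exists here; the expected step of a number no higher from compound 3 to compound 4 (the limit leaves the size open) is none beyond the scatter, since compound 3 already sits at the limit. Compound 4 is therefore expected near 300 mg/kg, within 150 mg/kg to 600 mg/kg, with a good chance that only a limit is reported again.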

Compound 4, dose for half-maximal effect: > 300 mg/kg
Compound 4: only a limit was reported; the forecaster's own chance of this, stated with the estimate: 70%; the middle value lies on the limit itself.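

No step can be read from compound 3 to compound 4 in this assay, since both compounds are reported only as a limit: the limit of > 300 mg/kg in this assay, at which 2 of the 4 values shown sit. The compounds shown leave open whether methyl in place of chloro on an aromatic carbon changes the dose needed in the open-chain compounds.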